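A Second Methoxy Placement on the Phenyl Substituent

A few compounds are considered here, and "the series" means these few. Any claim that something is new, unique, unknown or untested is made for them only; others in the source may bear on it.

Compound 1 `O=C(Nc1nn[nH]n1)c1cc(Cl)cc(-c2ccccc2)n1` was tested in a functional assay on the whole organism with Rattus norvegicus as the target, at a dose of 1 mg/kg by the oral route (on this read-out higher numbers stand for a stronger effect at the one dose given and lower numbers for a weaker effect), where compound 1 gives 40%. Among the measured compounds shown here, of the two numbers measured so far, this is the lower one. For the measured compounds named here, its only measured neighbour is compound 2 `COc1cccc(-c2cc(Cl)cc(C(=O)Nc3nn[nH]n3)n2)c1`, which differs by a methoxy in place of hydrogen on an aromatic carbon; in this assay compound 2 gives 51%. That single step, a number 11 percentage points higher from compound 1 to compound 2 (beyond the scatter), is the only one that bears on the question here.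

Compound 3 `COc1ccc(-c2cc(Cl)cc(C(=O)Nc3nn[nH]n3)n2)cc1` has not yet been measured. Relative to compound 1 the change is methoxy in place of hydrogen on an aromatic carbon, the same kind of swap seen in compound 2, though the two structures differ in where the group sits. Going by the values given here, since the one comparable step was a modest rise, a similar modest increase is expected, with added uncertainty because the placement differs: the expected step is a number 8 percentage points higher from compound 1 to compound 3 (within the scatter). Compound 3 is therefore estimated at 48%, with a range from 30% to 66%.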

Compound 3, a percentage reported as inhibition, in the whole organism at one dose (the size of the read-out at that dose, not a potency): 43%
Compound 3: the middle estimate sits 5 percentage points above what was measured, and the stated range covers the measured number.
By their numbers in this assay, from the lowest: compounds 1, 3 and 2 (each within the scatter of the next, the first and the last beyond it).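

In this assay, methoxy para to a large group gives a number 3 percentage points higher from compound 1 to compound 3 (within the scatter), so at this place the swap produces no change that can be told apart from the usual scatter, whereas the earlier step to compound 2 lies beyond it. Even so, compound 3 and compound 2 lie within the scatter of each other, so these numbers do not firmly separate the two placements of methoxy. Nothing available explains why the result came out this way.

Still open, as far as these compounds go, is whether a different group at this same place would move the number beyond the scatter, such as a hydroxyl, an amine, a carboxylic acid or a longer ether chain like ethoxy. From the compounds shown here alone, each number also comes from a single dose, so they show only the size of the effect at that dose, and whether the effect would be stronger or weaker at other doses remains unknown.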